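Propyl extension on the chain of compound 3

A few compounds are considered here, and "the series" means these few. Any claim that something is new, unique, unknown or untested is made for them only; others in the source may bear on it.

Measured so far:
- Compound 1, `CCc1cc2ccccc2nc1-c1cc(-c2ccccc2)no1`. In a functional assay on PC-3 cells (Homo sapiens) for inhibition, read by MTT assay, with a stated time of 24 h (a lower number here means a stronger inhibitor, a higher number a weaker inhibitor), compound 1 gives > 100000 nM, which is a limit of the assay.
- Compound 2, `CCCCCc1cc2ccccc2nc1-c1cc(-c2ccc(C)cc2)no1`. In this assay compound 2 gives > 100000 nM, again a limit.
- Compound 3, `CCc1cc2ccccc2nc1-c1cc(-c2ccc(C(F)(F)F)cc2)no1`. In this assay compound 3 gives > 100000 nM, also a limit.

Compound 3 therefore stands nowhere in particular on the numbers shown: all three values shown sit at the limit of > 100000 nM in this assay, at which 3 of the 3 values shown sit, and none is a measured number. For the measured compounds named here, the only measured step, a step that the two limits leave unreadable from compound 1 to compound 3, concerns trifluoromethyl in place of hydrogen on an aromatic carbon and is unreadable between two limits, so it says nothing about chain length.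

Compound 4, `CCCCCc1cc2ccccc2nc1-c1cc(-c2ccc(C(F)(F)F)cc2)no1`, differs from compound 3 by propyl in place of hydrogen on a saturated chain carbon, two bonds along the chain from an aromatic carbon. Going by the values given here, compound 2 carries the pentyl chain with methyl on the aromatic ring and sits at the limit as well; no step to it is readable. Among the compounds with values here, no measured step bears on the change from compound 3 to compound 4, and no step beyond the scatter can be expected in either direction. Compound 4 is expected to remain at the limit, with an estimated 100000 nM, range 30000 nM to 300000 nM, meaning an expected step of a number no higher from compound 3 to compound 4 (the limit leaves the size open).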

Compound 4, half-maximal inhibitory concentration: 30200 nM
Compound 4: middle estimate off by 3.3-fold (0.52 log units), on the high side, and the stated range covers the measured number.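

In this assay, for the compounds shown here, the chain position gives the first readable change: propyl in place of hydrogen on a saturated chain carbon, two bonds along the chain from an aromatic carbon, gives an at least 3.3-fold lower number from compound 3 to compound 4 (0.51 log units; beyond the scatter). With the pentyl chain in place, the aromatic position also becomes readable: trifluoromethyl in place of methyl on an aromatic carbon gives an at least 3.3-fold lower number from compound 2 to compound 4 (0.51 log units; beyond the scatter). Only compound 4 combines pentyl with trifluoromethyl, and the other compounds shown remain at a limit: the limit of > 100000 nM in this assay, at which 3 of the 4 values shown sit.

Going by these compounds, the true size of both steps remains open, since each starts from a limit, and the step between the two limits of the ethyl compounds cannot be read. Also open, on these data alone, is whether a longer chain than pentyl, or an amine in place of trifluoromethyl, would lower the number further.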